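Working notes: ethoxycarbonyl to carbamoyl change across two cores

This account rests on a few compounds, and the source may have more. Where it says the series, first, only, none or still open, it means among the compounds named here.

Compound 1 `CCOC(=O)c1cc(CBr)nn1[C@@H]1OC[C@@H](OC(C)=O)[C@@H](OC(C)=O)[C@H]1OC(C)=O` and compound 2 `CCOC(=O)c1cc(CBr)nn1[C@@H]1O[C@H](COC(C)=O)[C@@H](OC(C)=O)[C@H]1OC(C)=O` are built on two cores that hold the same atoms joined differently; the difference between the two cores is not broken down here. In a functional assay on HeLa cells (Homo sapiens), read by colorimetric assay, with a stated time of 72 h (on this read-out higher numbers stand for an effect only at larger amounts of compound and lower numbers for an effect already at smaller amounts), compound 1 gives 2 ug/mL, and compound 2 gives 2.5 ug/mL. For the measured compounds named here, compound 3 `CC(=O)O[C@@H]1[C@H](OC(C)=O)[C@H](OC(C)=O)CO[C@H]1n1nc(CBr)cc1C(N)=O` carries the change amino in place of ethoxy on a carbonyl carbon on the core of compound 1, and in this assay compound 3 gives 3 ug/mL; the resulting step is a 1.5-fold higher number from compound 1 to compound 3 (0.18 log units; within the scatter), the only measured instance of this change. Compound 4 `CC(=O)OC[C@H]1O[C@@H](n2nc(CBr)cc2C(N)=O)[C@H](OC(C)=O)[C@@H]1OC(C)=O` carries the same change, (amino in place of ethoxy on a carbonyl carbon), on the core of compound 2, at the same place. The step from compound 2 to compound 4 in this assay is expected to be a 1.4-fold higher number from compound 2 to compound 4 (0.15 log units; within the scatter), resting on a 1.5-fold higher number from compound 1 to compound 3 (0.18 log units; within the scatter). Compound 4 is therefore estimated at 3.5 ug/mL in this assay, with a range from 2 ug/mL to 6 ug/mL.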

Compound 4, concentration for half-maximal effect: 2 ug/mL
Estimate against measurement, compound 4: 1.8-fold (0.24 log units) above, within the range that was stated.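

In this assay the ethoxycarbonyl to carbamoyl change reads a 1.3-fold lower number from compound 2 to compound 4 (0.10 log units; within the scatter) on the second core. Set beside the step on the core of compound 1, this reading does not differ from it: the same change on two cores in this assay, a 1.5-fold higher number (0.18 log units; within the scatter) from compound 1 to compound 3 and a 1.3-fold lower number (0.10 log units; within the scatter) from compound 2 to compound 4, 1.9-fold (0.27 log units) apart, within the scatter of two such steps. The change therefore carries between these two cores with no detectable difference in this read-out, but with only two instances, each within the scatter, this shows neither a real effect of the change on either core nor that the agreement extends beyond the compounds shown.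

Still open, as far as these compounds go, is whether a carboxylic acid, or an ester with a longer chain, at the same place on the carbonyl carbon would give numbers beyond the scatter on either core.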